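The compounds below may be only part of what the source reports. "The series", "measured", "known", "first", "only" and "open" are said of these compounds alone.

In an assay on isolated protein for binding affinity to histamine H2 receptor (Homo sapiens) (on this read-out lower numbers stand for stronger inhibition and higher numbers for weaker inhibition), two compounds of one series have been measured so far. Compound 1 `O=C(c1ccc(OCCCN2CC[C@H](NS(=O)(=O)c3ccc(F)cc3)C2)cc1)C1CC1` gives 500 nM. Compound 2 `COc1ccc(S(=O)(=O)N[C@H]2CCN(CCCOc3ccc(C(=O)C4CC4)cc3)C2)cc1` gives 1000 nM. The two differ only in the group on the sulfonamide ring, and the step of a 2.0-fold higher number from compound 1 to compound 2 (0.30 log units; within the scatter) is a change that repeated measurement alone could produce, so the two numbers cannot be told apart with confidence.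

Compound 3 `O=C(c1ccc(OCCCN2CC[C@H](NS(=O)(=O)c3ccccc3F)C2)cc1)C1CC1` is not yet measured. Compared with compound 2 it carries 2-fluorophenyl in place of 4-methoxyphenyl on a sulfonyl sulfur. Among the measured compounds shown here, the only measured step that bears on this change is the one from compound 1 to compound 2, which swapped fluoro for methoxy on the same ring and stayed within the scatter. For the measured compounds named here, no measured step shows what a fluorine in a different place on that ring does, so the data give no ground to expect a shift in either direction beyond the scatter.

Compound 3 is therefore expected to give about 600 nM in this assay, with a plausible range from 200 nM to 2000 nM. The step of a 1.7-fold lower number from compound 2 to compound 3 (0.22 log units; within the scatter) is the estimated outcome, chosen because a 2.0-fold higher number from compound 1 to compound 2 (0.30 log units; within the scatter) was itself within the scatter.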

Compound 3, inhibition constant: 1550 nM
Beside the measured number, compound 3's estimate is 2.6-fold (0.41 log units) below it, within the range that was stated.
By their numbers in this assay, from the lowest: compounds 1, 2 and 3 (each within the scatter of the next, the first and the last beyond it).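

Among the compounds shown here, replacing 4-fluorophenyl with 2-fluorophenyl on the sulfonyl sulfur in this assay gives a 3.1-fold higher number from compound 1 to compound 3 (0.49 log units; beyond the scatter) and is the only step so far that lies beyond the scatter, though it is modest. The ring and its fluorine are present in both compounds, so this pair shows that the number can respond to where the fluorine sits on that ring. Replacing 4-methoxyphenyl with 2-fluorophenyl gives a 1.6-fold higher number from compound 2 to compound 3 (0.19 log units; within the scatter) and leaves compound 2 and compound 3 indistinguishable, even though the two groups differ in their atoms, and no measured evidence is available to account for either step.

The compounds shown carry only these three groups on the sulfonyl sulfur, so it remains open what a plain phenyl group, a chlorophenyl group or a short alkyl chain such as methyl would give there. On these data alone, it is also open whether the modest step between the two fluorophenyl compounds would persist if another part of the shared core were changed.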